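The compounds below may be only part of what the source reports. "The series", "measured", "known", "first", "only" and "open" are said of these compounds alone.

Compound 1 `COc1cc(NC(=O)c2ccc(Cl)cc2)ccc1NS(=O)(=O)C(F)(F)F` and compound 2 `COc1cc(NC(=O)c2ccc(Cl)c([N+](=O)[O-])c2)ccc1NS(=O)(=O)C(F)(F)F` share one core and differ in a single place: nitro in place of hydrogen on an aromatic carbon. In an ADME assay on RAW264.7 cells (Mus musculus) for cytotoxicity, read by MTT assay, with a stated time of 48 h (a lower number here means a stronger inhibitor, a higher number a weaker inhibitor), compound 1 gives 108000 nM. Compound 2 in this assay gives only a limit of the assay, > 250000 nM. The step of an at least 2.3-fold higher number from compound 1 to compound 2 (0.36 log units; beyond the scatter) is known only as far as the limit of > 250000 nM in this assay, at which 2 of the 3 values shown sit, allows. Compound 3 `CCS(=O)(=O)Nc1ccc(NC(=O)c2ccc(Cl)cc2)cc1Cl` is built on a different core; the difference between the two cores is not broken down here. In this assay compound 3 also gives only a limit, > 250000 nM. Compound 4 `CCS(=O)(=O)Nc1ccc(NC(=O)c2ccc(Cl)c([N+](=O)[O-])c2)cc1Cl` carries the same change on the core of compound 3, (nitro in place of hydrogen on an aromatic carbon). For compound 4 the expected step is a step that the limit leaves unreadable from compound 3 to compound 4, because compound 3 already gives > 250000 nM and the earlier step moved in the weaker direction. Compound 4 is therefore estimated at about 350000 nM in this assay, most likely reported as a limit again.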

Compound 4, half-maximal inhibitory concentration: 125000 nM
For compound 4 the middle estimate is 2.8-fold (0.45 log units) above the measured one, outside the stated range (below it).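

In this assay the nitro change gives an at least 2.0-fold lower number from compound 3 to compound 4 (0.30 log units; that floor lies within the scatter), so on this core the number falls, whereas on the core of compound 1 it rose. The change therefore does not carry over from one core to the other with the same direction or size: the same change on two cores in this assay, an at least 2.3-fold higher number (0.36 log units; beyond the scatter) from compound 1 to compound 2 and an at least 2.0-fold lower number (0.30 log units; that floor lies within the scatter) from compound 3 to compound 4, at least 4.6-fold (0.66 log units) apart, beyond the scatter of two such steps. Neither step has an exact size, only a floor, and two cores give no rule for the whole series: the limit of > 250000 nM in this assay, at which 2 of the 4 values shown sit.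

The compounds shown leave open which difference between the two cores goes with this reversal. They also leave open whether another group on the same aromatic carbon, such as an amine or a carboxylic acid, would split the two cores in the same way.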